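The source may hold more compounds than are shown below. What is called first, only, known or untested is meant among the compounds shown, and "the series" means these compounds.

In a functional assay on NCI-H460 cells (Homo sapiens) for inhibition, with a stated time of 72 h (a lower number here means a stronger inhibitor, a higher number a weaker inhibitor), compound 1 (`COc1cc(C(=O)c2ccc3[nH]ccc3c2)cc(OC)c1OC`) gives 112 nM and compound 2 (`COc1cc(C(=O)c2cccc3c2ccn3C)cc(OC)c1OC`) gives 28.8 nM. Among the measured compounds shown here, compound 3 (`COc1cc(C(=O)c2ccc3c(ccn3C(C)C)c2)cc(OC)c1OC`) gives 1600 nM, the highest of the three numbers so far. Compound 4 (`COc1cc(C(=O)c2ccc3c(ccn3CCC(=O)O)c2)cc(OC)c1OC`) has 2-carboxyethyl in place of isopropyl on an aromatic nitrogen. For the measured compounds named here, the only measured single-place step at this nitrogen is a 14-fold higher number from compound 1 to compound 3 (1.15 log units; beyond the scatter), a large rise on replacing hydrogen with isopropyl. Going by the values given here, no measured compound carries 2-carboxyethyl, so the size of this change is poorly constrained. A moderate further rise in this assay is expected, although a result near compound 3 remains possible. The estimated change is a 3.1-fold higher number from compound 3 to compound 4 (0.49 log units; beyond the scatter). Compound 4 is expected at 5000 nM, within an estimated range of 1200 nM to 25000 nM.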

Compound 4, half-maximal inhibitory concentration: > 10000 nM
Compound 4: no number, only a limit; the forecaster's own chance of this, stated with the estimate: 25%; middle value at least 2.0-fold (0.30 log units) from the limit.
By their numbers in this assay, from the lowest: compound 2; then compound 1; then compound 3. At a limit, above all of these: compound 4.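

In this assay, compound 4 has no number, only a limit of the assay: the limit of > 10000 nM in this assay, at which 1 of the 4 values shown sits. Placing 2-carboxyethyl instead of isopropyl on the aromatic nitrogen gives an at least 6.2-fold higher number from compound 3 to compound 4 (0.79 log units; beyond the scatter), and placing it instead of hydrogen gives an at least 89-fold higher number from compound 1 to compound 4 (1.95 log units; beyond the scatter). On the shared core, both substituents at this nitrogen therefore raise the number beyond the scatter, and the chain ending in a carboxylic acid raises it further than isopropyl.

Going by these compounds, how far compound 4 lies past its limit stays unknown. Also open, on these data alone, is whether an amine or a primary amide at the end of the same chain, or a plain propyl chain, would fare any better on this nitrogen.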